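Cyanoguanidine series: adding neopentyl to the isopropyl compound

The compounds below may be only part of what the source reports. "The series", "measured", "known", "first", "only" and "open" are said of these compounds alone.

Compound 2 `CC(C)/N=C(\NC#N)Nc1cccnc1` gives 2.5 mg/kg in a functional assay on the whole organism (blood, strain Wistar-Okamoto) with Rattus norvegicus as the target, with a stated time of 5 days (a higher number here means that more compound is needed for the effect, a lower number that less compound is needed), the lowest number among the three compounds measured. Compound 1 `CCC/N=C(\NC#N)Nc1cccnc1` gives 20 mg/kg and compound 3 `CC1(/N=C(\NC#N)Nc2cccnc2)CCC1` gives 50 mg/kg; the step of an 8.0-fold lower number from compound 1 to compound 2 (0.90 log units; beyond the scatter) and the step of a 20-fold higher number from compound 2 to compound 3 (1.30 log units; beyond the scatter) both lie beyond the scatter, so compound 2 is the most potent of the three in this assay.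

Compound 4 `CC(C)(C)CC(C)(C)/N=C(\NC#N)Nc1cccnc1` is not yet measured. It differs from compound 2 by neopentyl in place of hydrogen on a saturated chain carbon bound to a double-bonded nitrogen and two saturated chain carbons. The step that bears most on this is a 20-fold higher number from compound 2 to compound 3 (1.30 log units; beyond the scatter), where the group on the double-bonded nitrogen was likewise enlarged from isopropyl; the step of a 2.5-fold higher number from compound 1 to compound 3 (0.40 log units; beyond the scatter) points the same way. Both enlargements beyond isopropyl gave higher numbers. A higher number is therefore expected for compound 4 as well, with the step from compound 2 to compound 4 estimated at a 12-fold higher number from compound 2 to compound 4 (1.08 log units; beyond the scatter). Compound 4 is expected to give about 30 mg/kg in this assay, within a range from 8 mg/kg to 120 mg/kg.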

Compound 4, minimum effective dose: 50 mg/kg
Estimate against measurement, compound 4: 1.7-fold (0.22 log units) below; measured number inside the range.
By their numbers in this assay, from the lowest: compound 2; then compound 1; then compounds 3 and 4 (each within the scatter of the next).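

In this assay, neopentyl in place of hydrogen on this saturated chain carbon gives a 20-fold higher number from compound 2 to compound 4 (1.30 log units; beyond the scatter), so the rise in the number is not confined to the ring-bearing 1-methylcyclobutyl and also appears with an open-chain group. Compound 3 gives 50 mg/kg and compound 4 gives 50 mg/kg, so the larger open-chain group, with its 5 added carbons, stands at the same printed value as the ring-bearing group. No measurement available here accounts for the size of this step.

As far as these compounds go, it remains open whether a smaller group at this carbon, such as methyl or ethyl in place of hydrogen, already raises the number, or how much of the step from isopropyl needs the full neopentyl. Also open, from the compounds shown here alone, is how a hydroxyl or an amine in place of neopentyl at this carbon would read in this assay.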